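Swapping a Difluorophenyl for a Methoxyphenyl on the Sulfonyl

The source may hold more compounds than are shown below. What is called first, only, known or untested is meant among the compounds shown, and "the series" means these compounds.

Compound 1 `O=S(=O)(c1ccc(F)c(F)c1)c1cnc2c(F)cccc2c1-c1ccc(Cl)cc1` was tested in an ADME assay on microsomes from liver (Homo sapiens) for metabolic stability, tested at 2.5 uM (on this read-out higher numbers stand for fast clearance and lower numbers for slow clearance), where compound 1 gives 0.28 mL/min, the lowest of the three numbers here. Compound 3 `O=S(=O)(c1cc(Cl)cc(Cl)c1)c1cnc2cc(F)ccc2c1-c1ccccc1F` gives 0.93 mL/min, and compound 2 `COc1cccc(-c2c(S(=O)(=O)c3ccc(C)c(F)c3)cnc3c(F)cccc23)c1` gives 4.02 mL/min, both beyond the scatter above compound 1. Compound 4 `COc1ccc(S(=O)(=O)c2cnc3c(F)cccc3c2-c2ccc(Cl)cc2)cc1` has not yet been measured. Compared with compound 1, the change is 4-methoxyphenyl in place of 3,4-difluorophenyl on a sulfonyl sulfur. Going by the values given here, no measured pair shows this exact swap, so the expectation rests loosely on the spread of the three values, which all sit at or above compound 1. A moderate rise is expected, as a 4.3-fold higher number from compound 1 to compound 4 (0.63 log units; beyond the scatter). Compound 4 is estimated at 1.2 mL/min, with a range from 0.4 mL/min to 3.5 mL/min.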

Compound 4, intrinsic clearance in a liver preparation (reported as CLH), per the amount of preparation that the assay uses: 1.05 mL/min
The estimate for compound 4 lay 1.1-fold (0.06 log units) above the measured number; the range from low to high includes it.
By their numbers in this assay, from the lowest: compound 1; then compounds 3 and 4 (each within the scatter of the next); then compound 2.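

In this assay, going by these compounds alone, placing 4-methoxyphenyl in place of 3,4-difluorophenyl on a sulfonyl sulfur gives a 3.8-fold higher number from compound 1 to compound 4 (0.57 log units; beyond the scatter), the first step here in which only one place differs. It shows that this position alone can change the read-out modestly while the rest of compound 1 stays fixed. Nothing available explains the change. Going by these compounds, since the swap removes both fluorines and adds the methoxy at once, the contribution of each remains open. On these data alone, how an amine such as morpholine would read on the sulfonyl sulfur also remains open.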